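The source may hold more compounds than are shown below. What is called first, only, known or untested is meant among the compounds shown, and "the series" means these compounds.

Compound 1 `c1cncc(CNCCCCN(C[C@H]2Cc3ccccc3CN2)[C@H]2CCCc3cccnc32)c1`: in a functional assay on cells for agonist activity at C-X-C chemokine receptor type 4 (Homo sapiens), read by fluorescence and calcium flux, with a stated time of 90 s (a lower number here means that less compound is needed, a higher number that more compound is needed for the effect), compound 1 gives > 30000 nM, which is a limit of the assay and not a number.
Compound 2 `c1ccc2c(c1)CN[C@@H](CN(CCCCNCC1CCSCC1)[C@H]1CCCc3cccnc31)C2`: in this assay compound 2 gives > 30000 nM, again a limit.
Compound 3 `c1ccc2c(c1)CN[C@@H](CN(CCCCNC1CCCCC1)[C@H]1CCCc3cccnc31)C2`: in this assay compound 3 gives > 30000 nM, also a limit.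

Compound 3 therefore stands at the limit of this assay, and it shares that position with the two other values shown: the limit of > 30000 nM in this assay, at which 3 of the 3 values shown sit. The measured steps a step that the two limits leave unreadable from compound 1 to compound 3, a step that the two limits leave unreadable from compound 2 to compound 3 and a step that the two limits leave unreadable from compound 1 to compound 2 join compounds that all sit at the limit, so none of them has a readable size or direction.

Compound 4 `NCc1cccc(CN(C[C@H]2Cc3ccccc3CN2)[C@H]2CCCc3cccnc32)c1` differs from compound 3 by 3-(aminomethyl)phenyl in place of 3-(cyclohexylamino)propyl on a saturated chain carbon bound to an amine nitrogen. The three measured steps bear on this change only in that every variation of the group on that amine nitrogen tried so far has left the value at the limit; they give no readable size from which a direction could be taken. The estimate for compound 4 in this assay is therefore 30000 nM, with a range from 5000 nM to 100000 nM. The step of a number no higher from compound 3 to compound 4 (the limit leaves the size open) that this estimate means is expected to be none beyond the scatter, with the result most likely reported again as a limit.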

Compound 4, half-maximal effective concentration: > 30000 nM
Compound 4 ended at the assay's limit; the forecaster's own chance of this, stated with the estimate: 70%; the middle value lies on the limit itself.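

In this assay compound 4 gives > 30000 nM, which is a limit and not a number. Its steps to compound 1, compound 2 and compound 3 therefore cannot be read, since all four compounds share one position: the limit of > 30000 nM in this assay, at which 4 of the 4 values shown sit.

The compounds shown leave open whether any group on that amine nitrogen gives a readable value.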